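The source may hold more compounds than are shown below. What is called first, only, known or untested is meant among the compounds shown, and "the series" means these compounds.

In an ADME assay on MDBK cells (Bos taurus) for cytotoxicity (on this read-out lower numbers stand for higher toxicity in this test and higher numbers for lower toxicity in this test), the measured compounds read:

compound 1 `COc1ccc(Cn2ccc3nc(-c4ccccc4)nc-3c2)cc1`: > 100000 nM
compound 2 `c1ccc(CCCn2ccc3nc(-c4ccccc4)nc-3c2)cc1`: > 100000 nM
compound 3 `CC(C)N(CCn1ccc2nc(-c3ccccc3)nc-2c1)C(C)C`: > 100000 nM

Compound 3 has no numerical value, only the limit > 100000 nM. Compounds 1 and 2 also give only limits, so all three sit at the limit of > 100000 nM in this assay, at which 3 of the 3 values shown sit, and compound 3 cannot be ranked against the others.

Compound 4 `c1ccc(-c2nc3ccn(Cc4ccccn4)cc-3n2)cc1` is the next to be read. It has pyridin-2-yl in place of (diisopropylamino)methyl on a saturated chain carbon bound to an aromatic nitrogen.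

Within the data shown here, three measured steps bear on this change. The closest is a step that the two limits leave unreadable from compound 1 to compound 3, which alters the same place, as does a step that the two limits leave unreadable from compound 1 to compound 2. The third is a step that the two limits leave unreadable from compound 2 to compound 3, which alters the chain one carbon further along. None has a readable size, so they set no direction. Among the measured compounds shown here, they show only that three different groups on this chain all leave the read-out at the limit. For the measured compounds named here, compound 1, the one measured compound with a six-membered aromatic ring directly on this chain carbon, gives the limit > 100000 nM.

No step beyond the usual scatter is therefore expected in this assay, and a report of only a limit is the likeliest outcome. The expected change is a number no higher from compound 3 to compound 4 (the limit leaves the size open). For compound 4 the estimated value is 100000 nM, with an expected range from 30000 nM to 200000 nM.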

Compound 4, half-maximal cytotoxic concentration: > 100000 nM
Compound 4 ended at the assay's limit (the forecaster's own chance of this, stated with the estimate: 80%); the middle value lies on the limit itself.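

Compound 4, like compounds 1, 2 and 3, gives only a limit in this assay, and no step among these four compounds can be read: the limit of > 100000 nM in this assay, at which 4 of the 4 values shown sit. The compounds shown leave open whether any group on the saturated chain carbon bound to an aromatic nitrogen would give a numerical value in this assay, and how large such a step would be.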